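The source may hold more compounds than are shown below. What is called first, only, known or untested is meant among the compounds shown, and "the series" means these compounds.

The measured compounds:

Compound 1, `CC1(c2ccccc2)CC(=O)C(C2CC(c3ccc(-c4ccc(Br)cc4)cc3)Cc3ccccc32)=C(O)O1`, gives 2050 nM in a functional assay on SK-MEL-2 cells (Homo sapiens) for inhibition, with a stated time of 72 h; a higher number here means a weaker inhibitor, a lower number a stronger inhibitor.
Compound 2, `COc1ccc(C2Cc3ccccc3C(C3=C(O)OC(C)(c4ccccc4)CC3=O)C2)cc1`, gives in this assay only a limit of the assay, > 10000 nM.

Within the data shown here, compound 1 thus stands as the only real number in this small set; the other value sits at a limit of the assay (the limit of > 10000 nM in this assay, at which 1 of the 2 values shown sits). Among the measured compounds shown here, the single measured step, an at least 4.8-fold higher number from compound 1 to compound 2 (0.68 log units; beyond the scatter), came from putting methoxy in place of 4-bromophenyl on an aromatic carbon, a change at the outer aromatic end of the molecule.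

Compound 3, `CCC1(c2ccccc2)CC(=O)C(C2CC(c3ccc(-c4ccc(Br)cc4)cc3)Cc3ccccc32)=C(O)O1`, differs from compound 1 by methyl in place of hydrogen on a saturated chain carbon bound to a saturated ring carbon. For the measured compounds named here, the one measured step touches a different part of the molecule, so it offers no direct guide to this change, and no comparison in the set varies this carbon at all. With nothing pointing to a shift in either direction, the expectation for compound 3 in this assay is a step no larger than the usual scatter, a 1.2-fold higher number from compound 1 to compound 3 (0.09 log units; within the scatter). Compound 3 is therefore estimated at 2500 nM, with a likely range from 900 nM to 7000 nM.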

Compound 3, half-maximal inhibitory concentration: > 10000 nM
Compound 3: no number, only a limit (the forecaster's own chance of this, stated with the estimate: 15%); middle value at least 4.0-fold (0.60 log units) from the limit.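

Among these compounds, until this result, the only measured change lay at the outer aromatic end of the molecule, and nothing showed whether the other end of compound 1 could tolerate change. In this assay, putting methyl in place of hydrogen on a saturated chain carbon bound to a saturated ring carbon, which turns a methyl into an ethyl, gives an at least 4.8-fold higher number from compound 1 to compound 3 (0.68 log units; beyond the scatter), so even one added carbon at this position can matter as much as the far larger exchange at the aromatic end. The result for compound 3 is a limit of the assay and not a number, so the step has only a lower bound, and compound 1 remains the only compound here with a real number: the limit of > 10000 nM in this assay, at which 2 of the 3 values shown sit.

From the compounds shown here alone, how much inhibition is lost at this position remains unknown, as does whether any group here could do better than the methyl of compound 1. A bare hydrogen in place of that methyl, a longer chain such as propyl, or an oxygen-bearing group such as hydroxymethyl could each help show how much change this position accepts.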